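Same Swap of Substituent, Read Against a Low Baseline

This account rests on a few compounds, and the source may have more. Where it says the series, first, only, none or still open, it means among the compounds named here.

Measured compounds:
compound 1 `COc1ccc(-c2cn3ccnc3c(-c3ccc4ncn(C5CCCCC5)c4c3)n2)cc1`: 97.4%
compound 2 `Fc1ccc(-c2cn3ccnc3c(-c3ccc4ncn(C5CCCCC5)c4c3)n2)cc1`: 19.5%
compound 3 `COc1ccccc1-c1cn2ccnc2c(-c2ccc3ncn(C4CCCCC4)c3c2)n1`: 14.6%

The three measured compounds were tested in a functional assay on MDA-MB-468 cells (Homo sapiens) for inhibition, read by sulforhodamine B assay, with a stated time of 48 h, tested at 10 uM; a higher number here means more inhibition at the concentration tested (going by the name of the read-out), a lower number less inhibition. In this assay compound 1 gives 97.4%, compound 2 gives 19.5% and compound 3 gives 14.6%. From compound 1 to compound 2 the change is fluoro in place of methoxy on an aromatic carbon, and the step is a number 77.9 percentage points lower from compound 1 to compound 2 (beyond the scatter). From compound 1 to compound 3 the change is 2-methoxyphenyl in place of 4-methoxyphenyl on an aromatic carbon, and the step is a number 82.8 percentage points lower from compound 1 to compound 3 (beyond the scatter). Between compound 2 and compound 3 the step is a number 4.9 percentage points lower from compound 2 to compound 3 (within the scatter).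

Compound 4 `Fc1ccccc1-c1cn2ccnc2c(-c2ccc3ncn(C4CCCCC4)c3c2)n1` has not yet been measured. It differs from compound 3 by fluoro in place of methoxy on an aromatic carbon. This is the same kind of change as that from compound 1 to compound 2, but not the same: in the measured pair the fluoro stands para to a large group, whereas in compound 4 it stands ortho to a large group. The measured pair had a large step downward from a high starting point. Compound 3 starts low, so a step of that size is not available; compound 4 is expected to give a step of about a number 4.6 percentage points lower from compound 3 to compound 4 (within the scatter) from compound 3, resting on the small value of compound 3 14.6% and on the downward direction of a number 77.9 percentage points lower from compound 1 to compound 2 (beyond the scatter). For compound 4 the estimate is 10%, expected to lie between 0% and 30%.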

Compound 4, a percentage reported as inhibition, at one concentration (the size of the read-out at that concentration, not a potency) in the MDA-MB-468 assay: 27.6%
Estimate against measurement, compound 4: 17.6 percentage points below, and the stated range covers the measured number.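

In the MDA-MB-468 assay compound 4 gives 27.6%, and fluoro in place of methoxy does not carry over from the core of compound 1 to the core of compound 3, in size or in direction, and the new step on its own is a number 13 percentage points higher from compound 3 to compound 4 (beyond the scatter); the two steps set side by side read: the same change on two cores in the MDA-MB-468 assay, a number 77.9 percentage points lower (beyond the scatter) from compound 1 to compound 2 and a number 13 percentage points higher (beyond the scatter) from compound 3 to compound 4, 90.9 percentage points apart, beyond the scatter of two such steps

With fluoro on both, the 2-fluorophenyl and 4-fluorophenyl compounds stay close, the step being a number 8.1 percentage points higher from compound 2 to compound 4 (within the scatter), whereas the step from the 4-methoxyphenyl compound is a number 69.8 percentage points lower from compound 1 to compound 4 (beyond the scatter), so among these four compounds the high value stands with compound 1 alone. In a physicochemical assay for lipophilicity, using the shake flask method, in phosphate buffer, measured as octanol-water partition, with a stated time of 85 min, at pH 7.4 (a higher number here means a more lipophilic compound, a lower number a more polar compound), compound 3 gives 1.72 and compound 4 gives 1.95, the step being a number 0.23 log units higher from compound 3 to compound 4 (within the scatter), and one pair on each of two cores does not show how the change would run on any further core, nor why the two steps part.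

An amine, a hydroxyl or an ethoxy group in the place of the methoxy of compound 1 would speak to whether that high value is tied to methoxy itself, and the four compounds shown leave this open. They also leave open whether the fluoro step would hold with another group elsewhere on the shared core.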